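This account rests on a few compounds, and the source may have more. Where it says the series, first, only, none or still open, it means among the compounds named here.

Measured so far:
Compound 1 `CN(c1ccncc1)n1cccc1`: > 20 mg/kg
Compound 2 `c1ccc(CN(c2ccncc2)n2cccc2)cc1`: > 20 mg/kg

Both entries come from a functional assay on the whole organism with Mus musculus as the target (a lower number here means that less compound is needed, a higher number that more compound is needed for the effect), and each is a limit of the assay rather than a number. Compound 2 stands at > 20 mg/kg, which is a limit. The evidence so far amounts to the limit of > 20 mg/kg in this assay, at which 2 of the 2 values shown sit.

Compound 3 `C=CCN(c1ccncc1)n1cccc1` arises from compound 2 by a single change: vinyl in place of phenyl on a saturated chain carbon bound to a nitrogen on an aromatic ring. Within the data shown here, the one measured step at this place is a step that the two limits leave unreadable from compound 1 to compound 2, so it offers no size or direction to carry over. No shift beyond the scatter is therefore expected in this assay, and another limit is the likeliest report. The expected step is a step that the limit leaves unreadable from compound 2 to compound 3. Compound 3 is estimated at 25 mg/kg, with an expected range of 10 mg/kg to 60 mg/kg.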

Compound 3, dose for half-maximal effect: > 20 mg/kg
Compound 3 ended at the assay's limit; the forecaster's own chance of this, stated with the estimate: 70%; the middle value is on the limit's open side.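

The result for compound 3 is a limit, as are those for compound 1 and compound 2, so no step among these three compounds can be read in this assay. The compounds shown leave open how much of each is needed for the effect, and whether hydrogen, phenyl and vinyl at this place differ at all.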